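From oxy to amino on one chain carbon

This account rests on a few compounds, and the source may have more. Where it says the series, first, only, none or still open, it means among the compounds named here.

In a functional assay on NCI-H522 cells (Homo sapiens) for antiproliferative activity, read by sulforhodamine B assay, with a stated time of 48 h (on this read-out lower numbers stand for stronger inhibition and higher numbers for weaker inhibition), compound 2 (`C/C=C(\C)C(=O)O[C@H]1C=CC(=O)O[C@H]1COC(=O)[C@H](C)O`) gives 19000 nM and compound 1 (`C/C=C(\C)C(=O)O[C@H]1C=CC(=O)O[C@H]1CCC(=O)[C@H](C)O`) gives 26000 nM on the same read-out. The measured step is a 1.4-fold lower number from compound 1 to compound 2 (0.14 log units; within the scatter) so these two numbers cannot be told apart, and compound 2 sits level with compound 1 rather than ahead of it.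

Compound 3 (`C/C=C(\C)C(=O)O[C@H]1C=CC(=O)O[C@H]1CNC(=O)[C@H](C)O`) differs from compound 2 by one swap: ((1-hydroxyethyl)carbonyl)amino in place of ((1-hydroxyethyl)carbonyl)oxy on a saturated chain carbon bound to a saturated ring carbon on a saturated chain carbon bound to a saturated ring carbon. For the measured compounds named here, the one measured step changed the same place, so it is the only available guide. Going by the values given here, no measured compound yet carries the ((1-hydroxyethyl)carbonyl)amino group, which leaves this guide thin.

Among the compounds with values here, for compound 3, no step beyond the scatter is expected in this assay because a 1.4-fold lower number from compound 1 to compound 2 (0.14 log units; within the scatter) is the only change measured here. The estimated step is a 1.2-fold higher number from compound 2 to compound 3 (0.06 log units; within the scatter) and it remains an expectation until tested. Compound 3 is expected at 22000 nM with an estimated range from 9000 nM to 50000 nM on this read-out.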

Compound 3, half-maximal inhibitory concentration: 27000 nM
Estimate against measurement, compound 3: 1.2-fold (0.09 log units) below; the measured number falls inside the stated range.
By their numbers in this assay, from the lowest: compounds 2, 1 and 3 (each within the scatter of the next).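

Across this assay, the swap to ((1-hydroxyethyl)carbonyl)amino on a saturated chain carbon bound to a saturated ring carbon can now be read against two neighbours: against ((1-hydroxyethyl)carbonyl)oxy (a 1.4-fold higher number from compound 2 to compound 3 (0.15 log units; within the scatter)) and against ((1-hydroxyethyl)carbonyl)methyl (a 1.0-fold higher number from compound 1 to compound 3 (0.02 log units; within the scatter)). Compounds 1, 2 and 3 therefore cannot be told apart, so this place tolerates all three groups in this assay, and the move from 1 hydrogen-bond donor and 3 acceptors in the ((1-hydroxyethyl)carbonyl)oxy group to 2 donors and 2 acceptors in the ((1-hydroxyethyl)carbonyl)amino group comes with no step beyond the scatter. Nothing measured on these compounds offers an explanation for this flat result.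

The three compounds all keep the 1-hydroxyethyl end and the carbonyl, so they leave open whether this place stays as tolerant when those parts change. An amine in place of the hydroxyl, a carboxylic acid in place of the 1-hydroxyethyl end, or a longer chain on the same carbon could each test that on the shared core.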